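A few compounds are considered here, and "the series" means these few. Any claim that something is new, unique, unknown or untested is made for them only; others in the source may bear on it.

Measured in a functional assay on PC-3 cells (Homo sapiens) for antiproliferative activity, read by MTT assay, tested at 5 uM; on this read-out lower numbers stand for a weaker effect and higher numbers for a stronger effect at the one concentration tested:
compound 1 `COc1ccc(/C=N/NC(=O)c2cc(OC)c(OC)c(OC)c2)c(OC)c1` gives 22.2%;
compound 2 `COc1cc(C2=NN(C(C)=O)C(c3cc(Cl)cc(Cl)c3)O2)cc(OC)c1OC` gives 93.9%;
compound 3 `COc1cc(C(=O)N/N=C/c2cccc(C(F)(F)F)c2)cc(OC)c1OC` gives 79.8%.

Compound 2 stands highest of the three in this assay. Compound 3 lies nearest to it, yet its value falls below that of compound 2 by more than the scatter, and compound 1 lies far below, also beyond the scatter.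

Compound 4 `COc1cc(C2=NN(C(C)=O)C(c3ccc(F)c(F)c3)O2)cc(OC)c1OC` shares the core of compound 2 and differs only in one place: 3,4-difluorophenyl in place of 3,5-dichlorophenyl on a saturated ring carbon. Within the data shown here, no measured pair shows this change, so its size is unknown. Compound 4 is expected to remain active but somewhat below compound 2, with an estimated step of a number 18.9 percentage points lower from compound 2 to compound 4 (beyond the scatter) that is likely beyond the scatter. Compound 4 is therefore estimated at 75%, within a range from 45% to 95%.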

Compound 4, a percentage reported as inhibition, at one concentration (the size of the read-out at that concentration, not a potency): 46.9%
Compound 4: middle estimate off by 28.1 percentage points, on the high side, within the range that was stated.
By their numbers in this assay, from the lowest: compound 1; then compound 4; then compound 3; then compound 2.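

In this assay, the aryl group on the saturated ring carbon proves highly sensitive: putting 3,4-difluorophenyl in place of 3,5-dichlorophenyl gives a number 47 percentage points lower from compound 2 to compound 4 (beyond the scatter), a large step. The two groups match in heavy atoms, aromatic ring, hydrogen-bond counts and net charge, yet the read-out still moves this far. No available evidence explains the step.

This single pair changes both the halogen and its placement, so it cannot show which of the two matters. On these data alone, how 3,5-difluorophenyl, or a phenyl carrying an amine or a carboxylic acid, would behave on this ring carbon remains open.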